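The source may hold more compounds than are shown below. What is called first, only, known or untested is meant among the compounds shown, and "the series" means these compounds.

Three compounds share one core. Compound 1 `Cc1cc(O)c(C2=NN(c3ccc(S(N)(=O)=O)cc3)C(c3ccccc3O)C2)cc1Cl` bears a 2-hydroxyphenyl on a saturated ring carbon; in a functional assay on SR cells (Homo sapiens) for antiproliferative activity, with a stated time of 48 h (on this read-out lower numbers stand for stronger inhibition of growth and higher numbers for weaker inhibition of growth), compound 1 gives 2220 nM. Compound 2 `Cc1cc(O)c(C2=NN(c3ccc(S(N)(=O)=O)cc3)C(/C=C/c3ccccc3)C2)cc1Cl` carries a 2-phenylethenyl there, and in this assay compound 2 gives 12700 nM, a change that is a 5.7-fold higher number from compound 1 to compound 2 (0.76 log units; beyond the scatter). Compound 3 `COc1ccc(C2CC(c3cc(Cl)c(C)cc3O)=NN2c2ccc(S(N)(=O)=O)cc2)cc1OC` carries a 3,4-dimethoxyphenyl; in this assay compound 3 gives 2820 nM, the second highest of the three numbers, with steps of a 1.3-fold higher number from compound 1 to compound 3 (0.10 log units; within the scatter) and a 4.5-fold lower number from compound 2 to compound 3 (0.65 log units; beyond the scatter). Compound 4 `COc1ccc(C2CC(c3cc(Cl)c(C)cc3O)=NN2c2ccc(S(N)(=O)=O)cc2)c(OC)c1OC` differs from compound 3 by methoxy in place of hydrogen on an aromatic carbon. Among the compounds with values here, no measured step adds a methoxy, and the only step ending in compound 3 from a compound 1 stayed within the scatter. Compound 4 is therefore expected to show a 1.1-fold higher number from compound 3 to compound 4 (0.03 log units; within the scatter), an estimated 3000 nM with a range from 1200 nM to 7500 nM.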

Compound 4, concentration for 50% growth inhibition: 2470 nM
Beside the measured number, compound 4's estimate is 1.2-fold (0.08 log units) above it, and the stated range covers the measured number.
By their numbers in this assay, from the lowest: compounds 1, 4 and 3 (each within the scatter of the next); then compound 2.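

Adding a methoxy to the 3,4-dimethoxyphenyl group gives a 1.1-fold lower number from compound 3 to compound 4 (0.06 log units; within the scatter) in this assay, so this aromatic carbon accepts the extra group with no change beyond the scatter. The 2,3,4-trimethoxyphenyl group also matches the 2-hydroxyphenyl group, with a 1.1-fold higher number from compound 1 to compound 4 (0.05 log units; within the scatter), while the 2-phenylethenyl group stays clearly weaker, with a 5.1-fold lower number from compound 2 to compound 4 (0.71 log units; beyond the scatter) as the gap. Nothing measured here gives a reason for these steps. Still open, from the compounds shown here alone, is whether an amine or a carboxylic acid at this aromatic carbon, or a longer chain on the saturated ring carbon, would shift growth inhibition beyond the scatter.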